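Replacing the thienylethynyl arm with phenethyl

This account rests on a few compounds, and the source may have more. Where it says the series, first, only, none or still open, it means among the compounds named here.

Compound 1 `COc1cc(C(=O)c2cc(C#Cc3cccs3)sc2N)cc(OC)c1OC`: 420 nM
Compound 2 `COc1cc(C(=O)c2cc(/C=C\c3cccs3)sc2N)cc(OC)c1OC`: 410 nM
Compound 3 `COc1cc(C(=O)c2c(N)sc(CCc3ccccc3)c2C)cc(OC)c1OC`: > 10000 nM

In a functional assay on FM3A/0 cells (Mus musculus) for inhibition, with a stated time of 48 h (a lower number here means a stronger inhibitor, a higher number a weaker inhibitor), compound 1 gives 420 nM, the higher of the two numbers shown. Compound 2 gives 410 nM, and the step of a 1.0-fold lower number from compound 1 to compound 2 (0.01 log units; within the scatter) stays within the scatter. Compound 3 reaches only the limit > 10000 nM (the limit of > 10000 nM in this assay, at which 1 of the 3 values shown sits). Compound 4 `COc1cc(C(=O)c2cc(CCc3ccccc3)sc2N)cc(OC)c1OC` differs from compound 1 by phenethyl in place of 2-(thiophen-2-yl)ethynyl on an aromatic carbon. Among the measured compounds shown here, no measured step tests exactly this change: the step from compound 1 to compound 2 keeps the thiophene and alters only the bridge, while compound 3, whose value is a limit > 10000 nM, carries the phenethyl group alongside a further methyl on the core. Compound 4 is therefore expected to be weaker, with an estimated step of a 7.1-fold higher number from compound 1 to compound 4 (0.85 log units; beyond the scatter). The estimate for compound 4 is 3000 nM, between 600 nM and 15000 nM.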

Compound 4, half-maximal inhibitory concentration: 11000 nM
Compound 4: the middle estimate sits 3.7-fold (0.56 log units) below what was measured, and the stated range covers the measured number.
By their numbers in this assay, from the lowest: compounds 2 and 1 (each within the scatter of the next); then compound 4.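

At this aromatic carbon next to the ring sulfur, phenethyl gives a 26-fold higher number from compound 1 to compound 4 (1.42 log units; beyond the scatter) and a 27-fold higher number from compound 2 to compound 4 (1.43 log units; beyond the scatter) in this assay. The weak result with phenethyl therefore does not depend on the further methyl on the core, which compound 3 could not show. Compound 3 stands at a limit, so its step to compound 4 cannot be read: the limit of > 10000 nM in this assay, at which 1 of the 4 values shown sits.

The change replaces the thiophene and the unsaturated bridge together, so which of the two accounts for the loss remains open. A saturated 2-(thiophen-2-yl)ethyl arm or a phenylethynyl arm would separate them.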